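This account rests on a few compounds, and the source may have more. Where it says the series, first, only, none or still open, it means among the compounds named here.

In a functional assay on Jurkat cells (Homo sapiens) for inhibition, read by CCK-8 assay, with a stated time of 48 h (on this read-out lower numbers stand for stronger inhibition of growth and higher numbers for weaker inhibition of growth), compound 3 `CN1CCN(c2ccc(Nc3ncc(Cl)c(NCc4ccco4)n3)nc2)CC1` has no number, only a limit: compound 3 gives > 100000 nM. Compound 1 `CN1CCN(c2ccc(Nc3ncc(Cl)c(Nc4ccccc4)n3)nc2)CC1` also reaches only a limit, > 100000 nM. Compound 2 `CN1CCN(c2ccc(Nc3ncc(Cl)c(NCc4ccc(F)cc4)n3)nc2)CC1` reaches only a limit too, > 100000 nM. All the evidence therefore rests on (the limit of > 100000 nM in this assay, at which 3 of the 3 values shown sit). Compound 4 `Cc1cccc(Nc2nc(Nc3ccc(N4CCN(C)CC4)cn3)ncc2Cl)c1` differs from compound 3 by 3-methylphenyl in place of (furan-2-yl)methyl on a nitrogen on an aromatic ring, with 3-methylphenyl in place of (furan-2-yl)methyl on a nitrogen on an aromatic ring. Among the measured compounds shown here, three measured steps bear on this change: a step that the two limits leave unreadable from compound 1 to compound 3, a step that the two limits leave unreadable from compound 1 to compound 2 and a step that the two limits leave unreadable from compound 2 to compound 3. For the measured compounds named here, none has a readable size, so no step of definite size or direction can be expected in this assay beyond the scatter. The expected outcome is a number no higher from compound 3 to compound 4 (the limit leaves the size open). The estimate for compound 4 is 100000 nM, with an expected range of 20000 nM to 200000 nM.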

Compound 4, concentration for 50% growth inhibition: 15300 nM
Compound 4: middle estimate off by 6.5-fold (0.82 log units), on the high side, outside the stated range (below it).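

In this assay this nitrogen substituent now yields a measurable number: 3-methylphenyl in place of (furan-2-yl)methyl gives an at least 6.5-fold lower number from compound 3 to compound 4 (0.81 log units; beyond the scatter), and 3-methylphenyl in place of 4-fluorobenzyl gives an at least 6.5-fold lower number from compound 2 to compound 4 (0.81 log units; beyond the scatter). The smallest change, methyl in place of hydrogen on an aromatic carbon, gives an at least 6.5-fold lower number from compound 1 to compound 4 (0.81 log units; beyond the scatter). Each of these sizes is only a bound, set by a limit of the assay.

The steps among the other three compounds remain unreadable. From the compounds shown here alone, it remains open whether an ethyl, a methoxy or an amine in place of that methyl would carry the number lower still.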